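This account rests on a few compounds, and the source may have more. Where it says the series, first, only, none or still open, it means among the compounds named here.

Measured compounds:

Compound 1, `CC(=O)O[C@@]1(C)CCC(=O)[C@@H](C)CCC[C@]2(C)O[C@H]2C(=O)C(=C(C)C)CC1`: 21400 nM
Compound 2, `CC(=O)O[C@@]1(C)C/C=C2\O[C@H](C[C@@H]2C)C[C@]2(C)O[C@H]2C(=O)C(=C(C)C)CC1`: > 50000 nM, a limit of the assay
Compound 3, `CC(=O)O[C@@]1(C)CCC/C(C)=C/CC[C@@]2(C)O[C@@H]2C(=O)C(=C(C)C)CC1`: > 50000 nM, a limit of the assay

Among the measured compounds shown here, in a functional assay on NCI-H292 cells (Homo sapiens) for cytotoxicity, read by MTT assay, with a stated time of 24 h (on this read-out higher numbers stand for weaker inhibition and lower numbers for stronger inhibition), compound 1 gives 21400 nM, the only actual number in this small set. Compound 2 reaches only the limit of the assay, > 50000 nM, and no number beyond that is known. Compound 3 likewise stops at a limit, > 50000 nM. For the measured compounds named here, compound 1 therefore stands alone as the one compound with a measurable reading, while the two others sit at the limit of > 50000 nM in this assay, at which 2 of the 3 values shown sit, so no step between measured compounds can be stated.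

Compound 4, `CC(=O)O[C@@]1(C)CCC(=O)[C@H](C)CCC[C@]2(C)O[C@H]2C(=O)C(=C(C)C)CC1`, is the untested partner of compound 1. The change from compound 1 to compound 4 is the two compounds have the same atoms and bonds and differ only in configuration as drawn: 1 of 4 stereo elements differ; a stereocentre at a saturated ring carbon is drawn S in compound 1 and R in compound 4. The atoms and bonds are the same; only the drawn configuration at one saturated ring carbon is inverted.

Going by the values given here, with no measured step to lean on, the expectation is that such a single inversion moves the reading in this assay little, if at all, beyond the usual scatter, in either direction. Compound 4 is expected to give about 28000 nM, between 9000 nM and 60000 nM, an expected step of a 1.3-fold higher number from compound 1 to compound 4 (0.12 log units; within the scatter).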

Compound 4, half-maximal inhibitory concentration: 38900 nM
Compound 4: middle estimate off by 1.4-fold (0.14 log units), on the low side; the range from low to high includes it.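

Among the compounds shown here, compounds 1 and 4 are the only pair here that can be read side by side, and in this assay they give a 1.8-fold higher number from compound 1 to compound 4 (0.26 log units; within the scatter). For the compounds shown here, at this saturated ring carbon, then, drawing the stereocentre R rather than S leaves the reading within the usual scatter of repeated measurements, something the earlier compounds, with no step between them, could not show. The comparison is a clean one, since nothing but the drawn shape at this one carbon separates the two: the fact that compounds 1 and 4 differ only in the configuration as drawn.

Any steps to the compounds that stop at a limit of the assay cannot be read: the limit of > 50000 nM in this assay, at which 2 of the 4 values shown sit. The compounds shown also leave open whether a group such as an amine or a carboxylic acid on this same carbon would keep the reading where it is, and whether the R and S forms would still read alike with such a group in place.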